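Ethoxy to Trifluoromethyl on the Aniline Ring

The compounds below may be only part of what the source reports. "The series", "measured", "known", "first", "only" and "open" are said of these compounds alone.

- Compound 1 `O=C1C=C(Nc2cccc(F)c2)C(=O)c2c1nc1n2[C@H]2OC[C@@H](O)[C@H]2OC1` gives 7030 nM
- Compound 2 `CCOc1ccc(NC2=CC(=O)c3nc4n(c3C2=O)[C@H]2OC[C@@H](O)[C@H]2OC4)cc1` gives 3210 nM

In a functional assay on ECa-109 cells for inhibition, with ECa-109 cell line (Homo sapiens) as the target, read by sulforhodamine B assay (a lower number here means a stronger inhibitor, a higher number a weaker inhibitor), compound 2 holds the lower of the two numbers. Among the measured compounds shown here, the only measured step, a 2.2-fold lower number from compound 1 to compound 2 (0.34 log units; beyond the scatter), is modest but lies beyond the scatter.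

Compound 3 `O=C1C=C(Nc2ccc(C(F)(F)F)cc2)C(=O)c2c1nc1n2[C@H]2OC[C@@H](O)[C@H]2OC1` keeps the core of compound 2 and alters one group: trifluoromethyl in place of ethoxy on an aromatic carbon. Trifluoromethyl stands in place of ethoxy on an aromatic carbon, para to a large group.

For the measured compounds named here, no measured step makes this exact exchange, so the evidence is thin. Going by the values given here, compound 1, with its 3-fluorophenyl group, gives 7030 nM, and it is the only measured compound with fluorine on that ring. On that single comparison, a small move toward a higher number is expected in this assay, and the expected step is a 1.6-fold higher number from compound 2 to compound 3 (0.19 log units; within the scatter). For compound 3, the estimated value is 5000 nM, with an expected range of 1800 nM to 13000 nM.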

Compound 3, half-maximal inhibitory concentration: 5500 nM
Compound 3: middle estimate off by 1.1-fold (0.04 log units), on the low side; measured number inside the range.
By their numbers in this assay, from the lowest: compounds 2, 3 and 1 (each within the scatter of the next, the first and the last beyond it).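

In this assay, putting trifluoromethyl in place of ethoxy on the aromatic carbon para to a large group gives a 1.7-fold higher number from compound 2 to compound 3 (0.23 log units; within the scatter), so this exchange does not separate the two compounds at this position. The comparison with the 3-fluorophenyl compound gives a 1.3-fold lower number from compound 1 to compound 3 (0.11 log units; within the scatter), so compound 3 cannot be told apart from either neighbour, even though compound 1 and compound 2 lie beyond the scatter of each other. Nothing at hand bears on why these numbers fall as they do.

The compounds shown leave open whether an amine, a carboxylic acid or a chain longer than ethoxy on this carbon would move the number clearly away from that of compound 2. They also leave open how a fluorine on this same carbon would compare with the 3-fluorophenyl group.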